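Aminothiophene ketone piperazines: aryl swap on the ring nitrogen

The source may report more compounds than this note shows. Statements on the series, on what has been measured and on what is new or still open speak of the compounds shown alone.

Measured so far:
compound 1 `Nc1scc(CN2CCN(c3ccncc3)CC2)c1C(=O)c1ccc(Cl)cc1`, 1.4%
compound 2 `Nc1scc(CN2CCN(c3c(F)cccc3F)CC2)c1C(=O)c1cccc(C(F)(F)F)c1`, 1.3%

In a functional assay on CHO cells with adenosine receptor A1 (Homo sapiens) as the target, read by cAMP accumulation and immunoassay, with a stated time of 6 min, tested at 0.1 uM (on this read-out lower numbers stand for a stronger effect and higher numbers for a weaker effect at the one concentration tested), compound 1 gives 1.4%, and compound 2 gives 1.3%; the two values lie within the scatter of each other, so neither can be ranked against the other. Compound 3 `Nc1scc(CN2CCN(c3cccc(F)c3F)CC2)c1C(=O)c1ccc(Cl)cc1` differs from compound 1 in one place: 2,3-difluorophenyl in place of pyridin-4-yl on an amine nitrogen in a ring. Within the data shown here, no step between measured compounds bears on this change; compound 2, which also carries a difluorophenyl on the ring nitrogen, sits at the same low level as compound 1 in this assay. The expected step of a number 0.1 percentage points higher from compound 1 to compound 3 (within the scatter) is therefore none beyond the scatter. Compound 3 is estimated to give 1.5%, with a range from -8% to 12%.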

Compound 3, a percentage reported as activity, at one concentration (the size of the read-out at that concentration, not a potency): -5.2%
For compound 3 the middle estimate is 6.7 percentage points above the measured one, and the stated range covers the measured number.
By their numbers in this assay, from the lowest: compounds 3, 2 and 1 (each within the scatter of the next).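

In this assay, 2,3-difluorophenyl in place of pyridin-4-yl on the amine nitrogen in a ring gives a number 6.6 percentage points lower from compound 1 to compound 3 (within the scatter). Among these compounds, this is the first matched step at this position: the ring hetero atom and the hydrogen-bond acceptor of pyridin-4-yl leave, two fluorine atoms enter, and the read-out at the one concentration tested does not move beyond the scatter.

On these data alone, whether an aryl ring bearing an amine or a carboxylic acid, or a longer chain in place of the aryl ring, would hold this read-out remains open. Nothing shown explains why the read-out holds across this change.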